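This account rests on a few compounds, and the source may have more. Where it says the series, first, only, none or still open, it means among the compounds named here.

Compound 1 `COc1cc(C)cc(-c2c(-c3ccnc(-c4ccc(C(C)=O)cc4)c3)cnn2CC#N)c1` is examined in a functional assay on NCI-H23 cells (Homo sapiens) for inhibition, read by sulforhodamine B assay, with a stated time of 48 h; on this read-out lower numbers stand for stronger inhibition of growth and higher numbers for weaker inhibition of growth. In this assay compound 1 gives > 100000 nM, which is a limit of the assay rather than a measured number. Compound 2 `COc1cc(C)cc(-c2nn(CC#N)cc2-c2ccnc(-c3ccc(N(C)C)cc3)c2)c1` belongs to the same series. In this assay compound 2 gives > 100000 nM, again a limit and not a number. Both values therefore sit at the same bound, as the summary of the data makes plain: the limit of > 100000 nM in this assay, at which 2 of the 2 values shown sit. Nothing places compound 1 anywhere within the measured scale; it is known only that its growth-inhibiting concentration lies beyond that bound.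

Compound 3 `COc1cc(C)cc(-c2c(-c3ccnc(-c4ccc(N(C)C)cc4)c3)cnn2CC#N)c1` differs from compound 1 by a single exchange on the six-membered carbon ring, dimethylamino in place of acetyl on an aromatic carbon. Among the compounds with values here, since no measured step between compounds of this set exists, the size of the change from compound 1 to compound 3 can only be guessed from the shared limit. The expected step is a step that the limit leaves unreadable from compound 1 to compound 3, which is to say no change beyond the scatter that can be discerned. Compound 3 is accordingly expected to give about 150000 nM, within a range of 30000 nM to 600000 nM, with a strong likelihood that the assay reports only a limit.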

Compound 3, concentration for total growth inhibition: > 100000 nM
Compound 3 was reported as a limit (the forecaster's own chance of this, stated with the estimate: 80%); the middle value does not contradict the limit.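

No step can be read for the exchange of acetyl for dimethylamino between compound 1 and compound 3 in this assay, because each compound is reported only as a limit and not as a number: the limit of > 100000 nM in this assay, at which 3 of the 3 values shown sit.

The compounds shown leave open how far past that limit each one lies, and which structural change, if any, would give a measurable value in this assay here.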